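The compounds below may be only part of what the source reports. "The series", "measured", "known", "first", "only" and "open" are said of these compounds alone.

Working notes on the series. The shared core is set out in compound 1 `O=C(Nc1nc2ccccc2s1)c1cn(-c2ccccc2)nc1-c1ccc(F)cc1`, in compound 2 `O=C(Nc1nc2ccc(Cl)cc2s1)c1cn(-c2ccccc2)nc1-c1ccc(F)cc1` and in compound 3 `COc1ccc2nc(NC(=O)c3cn(-c4ccccc4)nc3-c3ccc(F)cc3)sc2c1`. In a functional assay on U-87MG ATCC cells for cytotoxicity against U-87 MG (Homo sapiens), read by MTT assay, with a stated time of 72 h (a higher number here means a weaker inhibitor, a lower number a stronger inhibitor), compound 1 gives 10700 nM and compound 2 gives 6770 nM, a change of a 1.6-fold lower number from compound 1 to compound 2 (0.20 log units; within the scatter). For compound 3 the assay reports only a limit, > 50000 nM, in line with the limit of > 50000 nM in this assay, at which 1 of the 3 values shown sits. Compound 3 thus stands at the weak end of the numbers shown: the steps of an at least 4.6-fold higher number from compound 1 to compound 3 (0.66 log units; beyond the scatter) and an at least 7.3-fold higher number from compound 2 to compound 3 (0.86 log units; beyond the scatter) both run to weaker inhibition, and their full size stays open because of the limit (the limit of > 50000 nM in this assay, at which 1 of the 3 values shown sits).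

Compound 4 `COc1ccc(-c2nn(-c3ccccc3)cc2C(=O)Nc2nc3ccc(OC)cc3s2)cc1` differs from compound 3 by methoxy in place of fluoro on an aromatic carbon. Among the measured compounds shown here, none of the measured steps touches this part of the molecule; the steps from compound 1 and compound 2 to compound 3 concern methoxy on an aromatic carbon elsewhere in the core. For the measured compounds named here, no measured step therefore bears on the step to compound 4, and no direction can be drawn from the data. Since compound 3 already sits at the limit, compound 4 is expected to remain near it, an expected step that the limit leaves unreadable from compound 3 to compound 4. Compound 4 is estimated at 70000 nM in this assay, range 20000 nM to 250000 nM, with a fair chance that only a limit is reported again.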

Compound 4, half-maximal inhibitory concentration: 5890 nM
Compound 4: middle estimate off by 12-fold (1.07 log units), on the high side; measured number below the stated range.
By their numbers in this assay, from the lowest: compounds 4, 2 and 1 (each within the scatter of the next). At a limit, above all of these: compound 3.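

The change from 4-fluorophenyl to 4-methoxyphenyl is the first shown at this place, and it gives an at least 8.4-fold lower number from compound 3 to compound 4 (0.92 log units; beyond the scatter) in this assay on a core that keeps its other methoxy group. Among the compounds shown here, this place, untouched by the earlier steps, can therefore move the read-out strongly, and that other methoxy group, whose addition ran to weaker inhibition in the step to compound 3, does not by itself fix the compound at the weak end. As far as these compounds go, compound 3 is reported only as a limit, so the full size of the step stays open: (the limit of > 50000 nM in this assay, at which 1 of the 4 values shown sits).

From the compounds shown here alone, it remains open whether 4-methoxyphenyl gives a similar step on the cores of compound 1 and compound 2, where no limit stands in the way. Also open, going by these compounds, is how a hydroxyl, an amine or a longer chain such as ethoxy would read at this place.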